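Working notes: 2-chlorophenyl to 3-chlorophenyl

The source may report more compounds than this note shows. Statements on the series, on what has been measured and on what is new or still open speak of the compounds shown alone.

Measured in a functional assay on A549 cells (Homo sapiens) for antiproliferative activity, read by MTT assay, with a stated time of 24 h; on this read-out higher numbers stand for weaker inhibition and lower numbers for stronger inhibition:
- compound 1 `Cc1ccccc1NNC(=O)c1ccccc1NS(=O)(=O)c1cnc(O)nc1O`: > 20000 nM (a limit)
- compound 2 `O=C(NNC(=O)c1ccccc1NS(=O)(=O)c1cnc(O)nc1O)c1ccccc1Cl`: 5290 nM

Among the compounds with values here, compound 2 holds the only actual number so far, at 5290 nM. Compound 1 reads > 20000 nM, which is a limit of this assay.

The next compound is compound 3 `O=C(NNC(=O)c1ccccc1NS(=O)(=O)c1cnc(O)nc1O)c1cccc(Cl)c1`, with one change: 3-chlorophenyl in place of 2-chlorophenyl on a carbonyl carbon. The two share the same atoms, joined differently.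

Within the data shown here, the only measured step is an at least 3.7-fold lower number from compound 1 to compound 2 (0.57 log units; beyond the scatter). It lies beyond the scatter, but it starts from a limit and concerns a different change, so it gives no direct measure here. With compound 2 at 5290 nM as the sole anchor, no step beyond the scatter is expected in this assay, and no direction is favoured. The expected change is a 1.1-fold lower number from compound 2 to compound 3 (0.02 log units; within the scatter). For compound 3 the estimated value is 5000 nM, with an expected range of 2000 nM to 14000 nM.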

Compound 3, half-maximal inhibitory concentration: 1260 nM
The estimate for compound 3 lay 4.0-fold (0.60 log units) above the measured number; measured number outside the range, below it.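

In this assay, 3-chlorophenyl in place of 2-chlorophenyl on the carbonyl carbon gives a 4.2-fold lower number from compound 2 to compound 3 (0.62 log units; beyond the scatter). Both compounds have the same atoms, so how the chlorophenyl is joined matters in this series by itself, which the earlier step, a change of group starting from a limit, could not show. Against compound 1 the new compound gives an at least 15-fold lower number from compound 1 to compound 3 (1.20 log units; beyond the scatter), a bound and not a true size, as compound 1 gives only a limit: the limit of > 20000 nM in this assay, at which 1 of the 3 values shown sits.

What lies behind the step between the two chlorophenyl compounds stays open, as these structures and this single read-out give no cause for it. Also open, going by these compounds, is whether a methoxy group or a fluorine in place of the chlorine on the same phenyl would keep, lose or extend the gain.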